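Semicarbazide series: aryl swap from compound 1 to compound 4

The compounds below may be only part of what the source reports. "The series", "measured", "known", "first", "only" and "open" are said of these compounds alone.

Compound 1 `COc1cc(NC(C)CCCNC(=O)NNC(=O)Nc2cccc(C(F)(F)F)c2)c2ncccc2c1` gives the lowest number of the three measured here; in a functional assay on MIA PaCa-2 cells (Homo sapiens) for inhibition, read by MTT assay, with a stated time of 72 h (on this read-out higher numbers stand for weaker inhibition and lower numbers for stronger inhibition), compound 1 gives 5600 nM. Compound 2 `COc1cc(NC(C)CCCNC(=O)NNC(=O)Nc2cccc(Cl)c2)c2ncccc2c1` gives 74000 nM, and compound 3 `COc1cc(NC(C)CCCNC(=O)Nc2cccc(O)c2)c2ncccc2c1` gives 46000 nM. The step of a 13-fold higher number from compound 1 to compound 2 (1.12 log units; beyond the scatter) is large, while a 1.6-fold lower number from compound 2 to compound 3 (0.21 log units; within the scatter) stays within the scatter. Compound 4 `COc1cc(NC(C)CCCNC(=O)NNC(=O)Nc2ccc(Cl)cc2)c2ncccc2c1` differs from compound 1 by 4-chlorophenyl in place of 3-(trifluoromethyl)phenyl on an amide-type nitrogen. Among the measured compounds shown here, the one measured step that bears on this, a 13-fold higher number from compound 1 to compound 2 (1.12 log units; beyond the scatter), also replaced trifluoromethyl with chloro and gave a large loss, so a step higher beyond the scatter is expected for compound 4 as well, of roughly similar size, an 8.9-fold higher number from compound 1 to compound 4 (0.95 log units; beyond the scatter). Compound 4 is therefore estimated at 50000 nM, with a range from 15000 nM to 150000 nM.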

Compound 4, half-maximal inhibitory concentration: >= 250000 nM
Compound 4 was reported as a limit; the forecaster's own chance of this, stated with the estimate: 10%; middle value at least 5.0-fold (0.69 log units) from the limit.
By their numbers in this assay, from the lowest: compound 1; then compounds 3 and 2 (each within the scatter of the next). At a limit, above all of these: compound 4.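

Compound 4 is a limit in this assay, not a number: the limit of >= 250000 nM in this assay, at which 1 of the 4 values shown sits. With chloro kept, 4-chlorophenyl in place of 3-chlorophenyl gives an at least 3.3-fold higher number from compound 2 to compound 4 (0.52 log units; beyond the scatter), so in these two compounds the place of the chloro matters, not only its presence. The other steps also reach beyond the scatter, with an at least 44-fold higher number from compound 1 to compound 4 (1.64 log units; beyond the scatter) and an at least 5.4-fold higher number from compound 3 to compound 4 (0.73 log units; beyond the scatter).

Going by these compounds, it remains open how 4-(trifluoromethyl)phenyl would compare with 3-(trifluoromethyl)phenyl at this amide-type nitrogen. On these data alone, an amine or a carboxylic acid on this aromatic ring also remains open.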